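Chloro to trifluoromethyl on the urea aryl of compound 3

The compounds below may be only part of what the source reports. "The series", "measured", "known", "first", "only" and "open" are said of these compounds alone.

Measured so far:
compound 1 `COc1cc(-c2nn(-c3cccc(NC(=O)Nc4cc(C(F)(F)F)cc(C(F)(F)F)c4)c3)cc2-c2ccncc2)ccc1Cl` — 1080 nM
compound 2 `COc1cc(-c2nn(-c3cccc(NC(=O)Nc4ccc(Cl)c(Cl)c4)c3)cc2-c2ccncc2)ccc1Cl` — 1100 nM
compound 3 `O=C(Nc1cccc(-n2cc(-c3ccncc3)c(-c3ccc(Cl)c(O)c3)n2)c1)Nc1ccc(Cl)c(Cl)c1` — 1380 nM

In a functional assay on MOLT-4 cells (Homo sapiens) for inhibition, read by sulforhodamine B assay, with a stated time of 48 h (on this read-out lower numbers stand for stronger inhibition of growth and higher numbers for weaker inhibition of growth), compound 3 gives 1380 nM, the highest of the three numbers, yet its gaps to compound 2 and to compound 1 both lie within the scatter, so the three compounds are not separated on this read-out. Going by the values given here, the one measured step that touches compound 3 is a 1.3-fold higher number from compound 2 to compound 3 (0.10 log units; within the scatter), a change at a different place.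

Compound 4 `O=C(Nc1cccc(-n2cc(-c3ccncc3)c(-c3ccc(Cl)c(O)c3)n2)c1)Nc1ccc(Cl)c(C(F)(F)F)c1` is not yet measured. It differs from compound 3 by trifluoromethyl in place of chloro on an aromatic carbon. Among the compounds with values here, no measured step carries exactly this exchange. What there is: in this assay compound 1, with two trifluoromethyl groups on the urea aryl, shows 1080 nM, and compound 2, with two chloro groups there, shows 1100 nM; the two values lie within the scatter of one another, which means a chloro to trifluoromethyl swap on that ring gave nothing resolvable on the methoxy core. On that basis the step of a 1.1-fold lower number from compound 3 to compound 4 (0.03 log units; within the scatter) is expected to stay within the scatter, with no direction claimed. The estimate for compound 4 in this assay is 1300 nM, with a range from 600 nM to 2800 nM.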

Compound 4, concentration for 50% growth inhibition: 777 nM
The estimate for compound 4 lay 1.7-fold (0.22 log units) above the measured number; the range from low to high includes it.
By their numbers in this assay, from the lowest: compounds 4, 1, 2 and 3 (each within the scatter of the next).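

Working notes on the urea aryl: in this assay, trifluoromethyl in place of chloro, ortho to a chloro group and meta to a large group, gives a 1.8-fold lower number from compound 3 to compound 4 (0.25 log units; within the scatter), the only reading in the compounds shown of this exchange with everything else held constant. The exchange replaces one chlorine with four heavy atoms (one carbon, three fluorine) and leaves the donor and acceptor counts unchanged, yet the step does not leave the scatter, so this position accepts the larger trifluoromethyl group without a resolved loss or gain in growth inhibition on this read-out. No supporting measurement bears on the size of this step or on what lies behind it.

The compounds shown hold only chloro and trifluoromethyl at this position, so a single step cannot say whether the same exchange would read alike on the core of compound 2, which carries a methoxy group where compound 3 has a hydroxyl. Going by these compounds, it also remains open how far this position stays permissive for groups of another kind, such as a nitrile, a primary amine or a carboxylic acid, and whether any of them would give a step beyond the scatter.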